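A few compounds are considered here, and "the series" means these few. Any claim that something is new, unique, unknown or untested is made for them only; others in the source may bear on it.

Compound 1 `Cc1cc(C)c2c(c1)CN(c1ccc3c(=O)cc(-c4ccccc4)oc3c1)CO2`: 11.3%
Compound 2 `O=c1cc(-c2ccccc2)oc2cc(N3COc4c(cccc4[N+](=O)[O-])C3)ccc12`: "not active" (no number reported)
Compound 3 `O=c1cc(-c2ccccc2)oc2cc(N3COc4c(Cl)cc(Cl)cc4C3)ccc12`: "not active" (no number reported)

In a functional assay on MCF7 cells (Homo sapiens) for inhibition, read by MTT assay, with a stated time of 48 h, tested at 7.5 ug/mL (a lower number here means less inhibition of growth, a higher number more inhibition of growth at the concentration tested), compound 1 gives 11.3%, a small figure. Compound 2 is reported in this assay only as "not active" (no number reported), with no number behind it. Compound 3 likewise is reported as "not active" (no number reported) without a number. On what is shown, compound 2 therefore stands among the compounds without any recorded growth inhibition, and only compound 1 carries a figure at all.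

Compound 4 `O=c1cc(-c2ccccc2)oc2cc(N3COc4ccccc4C3)ccc12` differs from compound 2 by hydrogen in place of nitro on an aromatic carbon. Among the compounds with values here, no measured pair shows this change. With two compounds reported without a number and one giving a small figure, the step is expected to be none beyond the scatter, or at most a small rise toward the level of compound 1. Compound 4 is thus expected to give about 10% in this assay, between 0% and 25%, with a real chance of again being reported as not active.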

Compound 4, percent growth inhibition at one concentration: 2.65%
Estimate against measurement, compound 4: 7.4 percentage points above; measured number inside the range.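

Within the data shown here, compound 2 has no number, so going from nitro to hydrogen in compound 4 gives no step that can be read. The compounds shown leave open whether any group on the shared core changes growth inhibition beyond the usual scatter. No measurement shown here offers an explanation for these results.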